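The source may report more compounds than this note shows. Statements on the series, on what has been measured and on what is new or still open speak of the compounds shown alone.

Compound 1 `Cc1cc(O)cc(-c2nn(CC#N)cc2-c2ccnc(-c3ccc(Oc4ccccc4)cc3)c2)c1`: -95%
Compound 2 `COc1cc(C)cc(-c2nn(CC#N)cc2-c2ccnc(-c3ccc(N(C)C)cc3)c2)c1`: -76%

In a functional assay on HCC 2998 cells (Homo sapiens) for cytotoxicity, read by sulforhodamine B assay, with a stated time of 48 h, tested at 10 uM (a lower number here means a stronger effect, a higher number a weaker effect of the compound at the concentration tested), compound 1 gives -95%, while compound 2 gives -76%, the higher of the two numbers, standing above compound 1 by a gap beyond the usual scatter. Compound 3 `Cc1cc(O)cc(-c2nn(CC#N)cc2-c2ccnc(-c3ccc(N(C)C)cc3)c2)c1` is not yet measured. It differs from compound 2 in one place: hydrogen in place of methyl on an oxygen on an aromatic ring. Among the measured compounds shown here, no measured pair shows this change on its own, so its size is open. A modest step toward a stronger effect is expected, partly because compound 1, which also carries the hydroxy, gives -95%, though a step within the scatter would not surprise. The expected step is a number 9 percentage points lower from compound 2 to compound 3 (within the scatter). Compound 3 is estimated at -85%, within -100% to -60%.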

Compound 3, a percentage reported as activity, at one concentration (the size of the read-out at that concentration, not a potency): -98%
Beside the measured number, compound 3's estimate is 13 percentage points above it; the range from low to high includes it.
By their numbers in this assay, from the lowest: compounds 3 and 1 (each within the scatter of the next); then compound 2.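

In this assay, among the compounds shown here, hydrogen in place of methyl on an oxygen on an aromatic ring, which turns methoxy into hydroxy, is now seen on its own for the first time, and it gives a number 22 percentage points lower from compound 2 to compound 3 (beyond the scatter). With the hydroxy in place, dimethylamino in place of phenoxy on an aromatic carbon gives a number 3 percentage points lower from compound 1 to compound 3 (within the scatter), so these two groups cannot be told apart in this read-out. Nothing measured here explains the gain that comes with the hydroxy.

On these data alone, it remains open whether an amine or a carboxylic acid in place of the hydroxy would keep this effect. As far as these compounds go, it also remains open whether the same step would appear in compounds carrying phenoxy instead of dimethylamino.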